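The source may hold more compounds than are shown below. What is called first, only, known or untested is meant among the compounds shown, and "the series" means these compounds.

Measured compounds:
compound 1 `N#CSc1cn([C@H]2C[C@H](O)[C@@H](CO)O2)c(=O)[nH]c1=O`: 78900 nM
compound 2 `Nc1nc2c(nc(I)n2COCCO)c(=O)[nH]1`: 111000 nM
compound 3 `CC1(C)C(CO)CC1Cn1nnc2c(Cl)nc(N)nc21`: > 200000 nM

In an ADME assay on L1210/0 cells (Mus musculus) for cytotoxicity, with a stated time of 48 h (on this read-out higher numbers stand for weaker inhibition and lower numbers for stronger inhibition), compound 1 gives the lower of the two numbers reported, and compound 2 sits within the usual scatter of it, so the two cannot be told apart. For compound 3 the result is the limit of > 200000 nM in this assay, at which 1 of the 3 values shown sits, a limit of the assay and not a number.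

Compound 4 `CCCCC#Cc1cn([C@H]2C[C@H](O)[C@@H](CO)O2)c(=O)[nH]c1=O` has not yet been measured in this assay. It differs from compound 1 in one place: hex-1-yn-1-yl in place of cyanosulfanyl on an aromatic carbon. For the measured compounds named here, no pair of measured compounds shows a comparable step, so the size can only be guessed; a moderate move toward stronger inhibition is expected, a 2.6-fold lower number from compound 1 to compound 4 (0.42 log units; beyond the scatter). Compound 4 is therefore expected to give about 30000 nM, somewhere between 5000 nM and 200000 nM.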

Compound 4, half-maximal inhibitory concentration: > 200000 nM
Compound 4: a limit, no number; the forecaster's own chance of this, stated with the estimate: 15%; middle value at least 6.6-fold (0.82 log units) away from the limit.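

In this assay, putting hex-1-yn-1-yl in place of cyanosulfanyl on this aromatic carbon gives an at least 2.5-fold higher number from compound 1 to compound 4 (0.40 log units; beyond the scatter). So the group at this position matters, and this change weakens inhibition on the shared core. The result for compound 4 is a limit and not a number, so how far the step really goes stays unknown: the limit of > 200000 nM in this assay, at which 2 of the 4 values shown sit.

Still open, going by these compounds, is whether a shorter alkyne chain, such as prop-1-yn-1-yl, or an amine on the same carbon would give a lower number than compound 1.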